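The compounds below may be only part of what the source reports. "The series", "measured", "known", "first", "only" and "open" are said of these compounds alone.

Three amides on the shared core have been measured in a functional assay on MCF7 cells (Homo sapiens) for antiproliferative activity, read by MTT assay, with a stated time of 24 h; a higher number here means a weaker inhibitor, a lower number a stronger inhibitor. Compound 1 `CCn1c(C(=O)NCCN)ccc1C(CC)(CC)c1ccc(OCS(=O)(=O)c2ccccc2)c(C)c1` gives 6470 nM, compound 2 `CCn1c(C(=O)N[C@@H](C)CO)ccc1C(CC)(CC)c1ccc(OCS(=O)(=O)c2ccccc2)c(C)c1` gives 10800 nM, and compound 3 `CCn1c(C(=O)N[C@H](CO)C(C)C)ccc1C(CC)(CC)c1ccc(OCS(=O)(=O)c2ccccc2)c(C)c1` gives 25500 nM. Compound 3 thus holds the highest number of the three, beyond the scatter from each of the others.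

Compound 4 `CCn1c(C(=O)N[C@@H](CO)CCCO)ccc1C(CC)(CC)c1ccc(OCS(=O)(=O)c2ccccc2)c(C)c1` brings (a group of 7 heavy atoms (5 carbon, 2 oxygen; no ring) in place of a group of 6 heavy atoms (5 carbon, 1 oxygen; no ring), on an amide-type nitrogen). All three measured steps concern this same amide-type nitrogen. The first, a 1.7-fold higher number from compound 1 to compound 2 (0.22 log units; within the scatter), stays within the scatter, while a 3.9-fold higher number from compound 1 to compound 3 (0.60 log units; beyond the scatter) and a 2.4-fold higher number from compound 2 to compound 3 (0.37 log units; beyond the scatter) are both modest. Going by the values given here, no large step has been seen here, and no measured compound carries the entering group, so the steps only suggest a likely size.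

The group that leaves is the one formed in a 2.4-fold higher number from compound 2 to compound 3 (0.37 log units; beyond the scatter), so a modest move toward a lower number in this assay is expected, though one within the scatter remains possible. The expected step is a 2.1-fold lower number from compound 3 to compound 4 (0.33 log units; beyond the scatter). For compound 4 the estimate is 12000 nM, with an expected range of 5500 nM to 26000 nM.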

Compound 4, half-maximal inhibitory concentration: 29600 nM
Compound 4: the middle estimate sits 2.5-fold (0.39 log units) below what was measured, outside the stated range (above it).
By their numbers in this assay, from the lowest: compounds 1 and 2 (each within the scatter of the next); then compounds 3 and 4 (each within the scatter of the next).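

In this assay, putting the group of 7 heavy atoms in place of 1-(hydroxymethyl)-2-methylpropyl on the amide-type nitrogen gives (a 1.2-fold higher number from compound 3 to compound 4 (0.06 log units; within the scatter)), so compound 3 and compound 4 cannot be told apart, even with 2 hydrogen-bond donors and 2 acceptors in the entering group against 1 of each in the group that leaves. The larger group of compound 4 also stands apart from the smaller groups, with (a 2.7-fold higher number from compound 2 to compound 4 (0.44 log units; beyond the scatter)) and (a 4.6-fold higher number from compound 1 to compound 4 (0.66 log units; beyond the scatter)), so across these four compounds the higher numbers go with the larger groups on this nitrogen, and none of the four goes against this. No evidence on the cause of this result is available.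

On these data alone, whether a carboxylic acid, a tertiary amine or a longer chain ending in a primary amine on this nitrogen would give a number clearly lower than that of compound 1 stays open. As far as these compounds go, how the opposite configuration at the defined stereocentre of compound 4 would read is also open.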